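A few compounds are considered here, and "the series" means these few. Any claim that something is new, unique, unknown or untested is made for them only; others in the source may bear on it.

Compound 1 `COc1cc(-c2nn(-c3cccc(NC(=O)c4cccc(C(F)(F)F)c4)c3)cc2-c2ccncc2)ccc1Cl` is one of two compounds with a number in a functional assay on HOP-92 cells (Homo sapiens) for inhibition, read by sulforhodamine B assay, with a stated time of 48 h; on this read-out lower numbers stand for stronger inhibition of growth and higher numbers for weaker inhibition of growth. In this assay compound 1 gives 3120 nM, the highest of the two numbers. The other, compound 2 `O=C(Nc1cccc(-n2cc(-c3ccncc3)c(-c3ccc(Cl)c(O)c3)n2)c1)Nc1ccc(Cl)c(C(F)(F)F)c1`, gives 1460 nM in this assay, a lower number that lies beyond the scatter of the method. Compound 3 `COc1cc(-c2nn(-c3cccc(NC(=O)Nc4ccc(Cl)c(Cl)c4)c3)cc2-c2ccncc2)ccc1Cl` shares the core of compound 1 and differs from it in one place: (3,4-dichlorophenyl)amino in place of 3-(trifluoromethyl)phenyl on a carbonyl carbon. For the measured compounds named here, no step between measured compounds covers this change, so its size cannot be read from a prior pair. Compound 2 carries a carbamoyl-type link of the same sort as compound 3 and sits lower than compound 1, so a modest move to a lower number is expected for compound 3, with the step from compound 1 estimated as a 2.0-fold lower number from compound 1 to compound 3 (0.29 log units; within the scatter). Compound 3 is therefore expected to give about 1600 nM in this assay, in a range from 600 nM to 4500 nM.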

Compound 3, concentration for total growth inhibition: 1470 nM
The estimate for compound 3 lay 1.1-fold (0.04 log units) above the measured number, and the stated range covers the measured number.
By their numbers in this assay, from the lowest: compounds 2 and 3 (each within the scatter of the next); then compound 1.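

For the compounds shown here, at this position on a carbonyl carbon, (3,4-dichlorophenyl)amino in place of 3-(trifluoromethyl)phenyl gives the first direct reading of a single change on the shared core: in this assay it produces a 2.1-fold lower number from compound 1 to compound 3 (0.33 log units; beyond the scatter), a modest step. The entering group brings an amide-type nitrogen and a hydrogen-bond donor absent from the leaving group, while its chlorine atoms replace the trifluoromethyl group, so this one step covers both the link and the ring substituents. No available evidence accounts for the size or direction of the step.

The compounds shown leave open how much of the step belongs to the link and how much to the ring substituents, which (3-(trifluoromethyl)phenyl)amino at the same place would help to separate. As far as these compounds go, how a morpholine or a carboxylic acid would read there also remains open.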